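Swapping the 2-ethylbutyl chain for an amino substituent

This account rests on a few compounds, and the source may have more. Where it says the series, first, only, none or still open, it means among the compounds named here.

Measured so far:
- compound 1 `CCc1nc(-c2ccc(Cl)cc2Cl)c(CC)nc1NC(C1CC1)C1CC1`: 3.7 nM
- compound 2 `CCc1nc(-c2ccc(OC(F)(F)F)cc2OC)c(OC)nc1NC(CC)CC`: 6.1 nM
- compound 3 `CCc1nc(-c2ccc(Cl)cc2Cl)c(CC)nc1CC(CC)CC`: 68 nM

In an assay on IMR-32 cells for displacement of a labelled ligand from corticotropin-releasing factor receptor 1 (Homo sapiens), read by scintillation counting, with a stated time of 2 h (on this read-out higher numbers stand for weaker inhibition and lower numbers for stronger inhibition), compound 3 gives the highest number of the three, the weakest binding seen in this small set, with compound 2 the nearest and compound 1 the furthest. Going by the values given here, the only single-point step known is an 18-fold higher number from compound 1 to compound 3 (1.26 log units; beyond the scatter), where the (dicyclopropylmethyl)amino group was replaced by 2-ethylbutyl and the number rose sharply.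

Compound 4 `CCCN(CCN(C)C)c1nc(CC)c(-c2ccc(Cl)cc2Cl)nc1CC` takes the reverse direction: (2-(dimethylamino)ethyl)(propyl)amino in place of 2-ethylbutyl on an aromatic carbon. The entering group is, like those of compound 1 and compound 2, an amino substituent, though here bearing two chains rather than one, and it carries two hydrogen-bond acceptors where 2-ethylbutyl has none. Among the compounds with values here, the one bearing step says removing an amino group cost much; restoring one is expected to win a good part of that back, so compound 4 is estimated to show a clearly lower number, a 6.8-fold lower number from compound 3 to compound 4 (0.83 log units; beyond the scatter), landing near 10 nM with a likely range from 2 nM to 50 nM.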

Compound 4, inhibition constant: 1540 nM
For compound 4 the middle estimate is 150-fold (2.19 log units) below the measured one; measured number above the stated range.
By their numbers in this assay, from the lowest: compounds 1 and 2 (each within the scatter of the next); then compound 3; then compound 4.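

In this assay, an amino link at this position does not by itself bring strong binding: a 23-fold higher number from compound 3 to compound 4 (1.36 log units; beyond the scatter), so this group does worse than the 2-ethylbutyl chain it replaces. The choice of amino substituent matters greatly, with a 420-fold higher number from compound 1 to compound 4 (2.62 log units; beyond the scatter), where (2-(dimethylamino)ethyl)(propyl)amino stands in place of (dicyclopropylmethyl)amino. The low numbers of compound 1 and compound 2 had suggested that an amino group here was enough, but compound 4 shows that what the nitrogen carries decides the outcome.

No measurement shown here accounts for this loss of binding. The entering group brings both a second chain on the nitrogen and a dimethylamino end, and these remain unseparated; a dipropylamino group on the same core would help tell them apart.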